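This account rests on a few compounds, and the source may have more. Where it says the series, first, only, none or still open, it means among the compounds named here.

Measured so far:
- compound 1 `CC(C)[C@H](NC(=O)COc1cccc2ccccc12)C(=O)N[C@@H](CC(=O)O)C(=O)COc1ccc2ccccc2c1`; in a functional assay on Jurkat cells (Homo sapiens) (a higher number here means a weaker inhibitor, a lower number a stronger inhibitor), compound 1 gives > 100000 nM, which is a limit of the assay and not a number.
- compound 2 `CC(C)[C@H](NC(=O)COc1cccc2ccccc12)C(=O)N[C@@H](CC(=O)O)C(=O)COc1ccc(-c2ccccc2)cc1`; in this assay compound 2 gives 87900 nM.
- compound 3 `CC(C)[C@H](NC(=O)COc1cccc2ccccc12)C(=O)N[C@@H](CC(=O)O)C(=O)COc1ccc(C(F)(F)F)cc1`; in this assay compound 3 gives > 100000 nM, again a limit of the assay rather than a number.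

Compound 3 therefore stands at the upper edge of what this assay reports; (the limit of > 100000 nM in this assay, at which 2 of the 3 values shown sit), so the series as a whole sits at or near that edge. Compound 4 `CC(C)[C@H](NC(=O)COc1cccc2ccccc12)C(=O)N[C@@H](CC(=O)O)C(=O)COc1cc(F)c(F)cc1F` is the next step from compound 3: 2,4,5-trifluorophenyl in place of 4-(trifluoromethyl)phenyl on an oxygen on a saturated carbon.

The measured steps that bear on this change are the ones into compound 3. The step of an at least 1.1-fold higher number from compound 2 to compound 3 (0.05 log units; that floor lies within the scatter) has only a floor, and the step that the two limits leave unreadable from compound 1 to compound 3 cannot be read at all; the step of an at least 1.1-fold lower number from compound 1 to compound 2 (0.05 log units; that floor lies within the scatter) likewise has only a floor within the scatter. Nothing among these steps points to a readable move in either direction, and the exchange of one aryl group for another on the same oxygen has so far left the value at or near the limit.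

For compound 4 the expectation is accordingly a value again at or near the limit of this assay, estimated at 100000 nM with a range from 30000 nM to 300000 nM. The step this estimate means for compound 4 is a number no higher from compound 3 to compound 4 (the limit leaves the size open), expected to be no larger than the scatter.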

Compound 4, half-maximal inhibitory concentration: 39300 nM
Beside the measured number, compound 4's estimate is 2.5-fold (0.41 log units) above it, within the range that was stated.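

In this assay, the aryl group on this oxygen proves able to move the value off the limit: the change to 2,4,5-trifluorophenyl gives an at least 2.5-fold lower number from compound 3 to compound 4 (0.40 log units; beyond the scatter) and an at least 2.5-fold lower number from compound 1 to compound 4 (0.40 log units; beyond the scatter), both floors set by a limit at one end. Against 4-phenylphenyl, the one other aryl group with a number, the same change gives a 2.2-fold lower number from compound 2 to compound 4 (0.35 log units; beyond the scatter), the first step in the series with a full size beyond the scatter. These moves remain small on the scale of the assay, and the other aryl groups stay at its edge: the limit of > 100000 nM in this assay, at which 2 of the 4 values shown sit.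

Open, going by these compounds, is whether the step follows from the three fluorine atoms on the ring or from the loss of trifluoromethyl. Also open, on these data alone, is how an unsubstituted phenyl, a methoxy group or an amine on this ring would read.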